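The source may hold more compounds than are shown below. What is called first, only, known or untested is meant among the compounds shown, and "the series" means these compounds.

Measured so far in a functional assay on MCF7 cells (Homo sapiens) for inhibition, read by sulforhodamine B assay; on this read-out lower numbers stand for stronger inhibition and higher numbers for weaker inhibition:
compound 1 `COc1ccccc1NC1=CC(=O)c2c(nc3n2[C@H]2OC[C@@H](O)[C@H]2OC3)C1=O` gives 6580 nM
compound 2 `CCCc1ccc(NC2=CC(=O)c3nc4n(c3C2=O)[C@H]2OC[C@@H](O)[C@H]2OC4)cc1` gives 4660 nM
compound 3 `O=C1C=C(Nc2ccc(Br)cc2)C(=O)c2c1nc1n2[C@H]2OC[C@@H](O)[C@H]2OC1` gives 2580 nM

Among these three, compound 1 stands with the highest number. Compound 2 lies within the scatter of compound 1, whereas compound 3 sits lower by a margin beyond the scatter. Within the data shown here, the only single-point step among the measured compounds is a 1.8-fold lower number from compound 2 to compound 3 (0.26 log units; within the scatter), and it moved the number only within the scatter.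

Compound 4 `O=C1C(Nc2ccc(I)cc2)=CC(=O)c2c1nc1n2[C@H]2OC[C@@H](O)[C@H]2OC1` differs from compound 1 by 4-iodophenyl in place of 2-methoxyphenyl on an amine nitrogen. Among the measured compounds shown here, no measured pair isolates this exact exchange of one aryl ring for another. The nearest guidance comes from compound 3, which carries bromo on its aromatic ring and gave the lowest number of the set, together with the step in which bromo replaced propyl without a change beyond the scatter. Compound 4 brings an iodine on its ring, and its number is therefore expected to come out near that of compound 3 rather than near compound 1.

On this basis compound 4 is expected to give 2500 nM in this assay, with a likely range from 1000 nM to 6000 nM. This corresponds to an expected step of a 2.6-fold lower number from compound 1 to compound 4 (0.42 log units; beyond the scatter), a lowering that should exceed the scatter.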

Compound 4, half-maximal inhibitory concentration: 3890 nM
Compound 4: the middle estimate sits 1.6-fold (0.19 log units) below what was measured; low and high end bracket the measured number.
By their numbers in this assay, from the lowest: compounds 3, 4, 2 and 1 (each within the scatter of the next, the first and the last beyond it).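

On the shared core, the exchange of 2-methoxyphenyl for 4-iodophenyl on the amine nitrogen gives a 1.7-fold lower number from compound 1 to compound 4 (0.23 log units; within the scatter) in this assay. Among these compounds, this is the first measured step at this nitrogen that replaces one whole aryl group with another, and the change in group, which also removes the hydrogen-bond acceptor counted in 2-methoxyphenyl, leaves the number within the scatter. The step alters both the substituent and its place on the ring, so its small size does not show how each change acts alone, and nothing here bears on why the number stayed within the scatter.

The compounds shown leave open whether the same substituent would behave differently at another place on the ring, and how a plain phenyl group on this nitrogen would compare with the substituted rings. They also do not tell whether a ring carrying an amine or a carboxylic acid would move the number in this assay beyond the scatter, or whether a group other than an aryl ring, such as a longer alkyl chain, would do so on this nitrogen.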